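Cytotoxicity limits across three measured compounds and one unmeasured

The source may report more compounds than this note shows. Statements on the series, on what has been measured and on what is new or still open speak of the compounds shown alone.

Measured compounds:
Compound 1, `CC(C)C[C@H](NC(=O)OCCc1cccc(Cl)c1)C(=O)N[C@H](C=O)C[C@@H]1CCNC1=O`. In an ADME assay on Vero C1008 cells (Chlorocebus sabaeus) for cytotoxicity, read by luminescence and CellTiter-Glo, with a stated time of 24 h (a higher number here means that more compound is tolerated, a lower number that less compound is tolerated), compound 1 reaches only the limit > 200000 nM.
Compound 2, `CC(C)C[C@H](NC(=O)O[C@@H](C)c1ccccc1)C(=O)N[C@H](C=O)C[C@@H]1CCNC1=O`. In this assay compound 2 reaches only the limit > 200000 nM.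
Compound 3, `O=C[C@H](C[C@@H]1CCNC1=O)NC(=O)[C@H](CC1CC1)NC(=O)OCCc1cccc(Cl)c1`. In this assay compound 3 reaches only the limit > 200000 nM.

Among the compounds with values here, every value so far sits at a limit, (the limit of > 200000 nM in this assay, at which 3 of the 3 values shown sit), so no ranking among the three is readable. Compound 2 differs from compound 1 by 1-phenylethyl in place of 2-(3-chlorophenyl)ethyl on an oxygen next to a carbonyl group, and the step that the two limits leave unreadable from compound 1 to compound 2. The two cores differ by cyclopropyl in place of isopropyl on a saturated chain carbon, two bonds along the chain from an amide-type nitrogen and a carbonyl carbon, and the step that the two limits leave unreadable from compound 1 to compound 3.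

Compound 4, `C[C@H](OC(=O)N[C@@H](CC1CC1)C(=O)N[C@H](C=O)C[C@@H]1CCNC1=O)c1ccccc1`, has not yet been measured. It differs from compound 3 by 1-phenylethyl in place of 2-(3-chlorophenyl)ethyl on an oxygen next to a carbonyl group, the same change as that from compound 1 to compound 2, now made on the core of compound 3. The expected step of a number no higher from compound 3 to compound 4 (the limit leaves the size open) is small, because the earlier step that the two limits leave unreadable from compound 1 to compound 2 left both partners at the limit (the limit of > 200000 nM in this assay, at which 3 of the 3 values shown sit). Compound 4 is therefore expected to give about 200000 nM in this assay, and most likely only a limit again.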

Compound 4, half-maximal cytotoxic concentration: > 200000 nM
Compound 4: a limit, no number; the forecaster's own chance of this, stated with the estimate: 85%; the middle value lies on the limit itself.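

In this assay compound 4 gives > 200000 nM, which is a limit and not a number, so neither its step from compound 3 nor its step from compound 2 can be read: the limit of > 200000 nM in this assay, at which 4 of the 4 values shown sit.

The compounds shown leave open at what concentration any of compounds 1, 2, 3 and 4 becomes cytotoxic, and whether either change alters this.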